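Piperidine nitrogen substituents in a methylsulfonylpyrazine series

The source may report more compounds than this note shows. Statements on the series, on what has been measured and on what is new or still open speak of the compounds shown alone.

Measured so far:
compound 1, `C[C@H](CF)OC(=O)N1CCC(O[C@H]2CC[C@H](Oc3cnc(S(C)(=O)=O)cn3)CC2)CC1`: 317 nM
compound 2, `CS(=O)(=O)c1cnc(O[C@H]2CC[C@H](OC3CCN(C(=O)C4(C(F)(F)F)CCCC4)CC3)CC2)cn1`: 108 nM
compound 3, `CS(=O)(=O)c1cnc(O[C@H]2CC[C@H](OC3CCN(CC4(C(F)(F)F)CC4)CC3)CC2)cn1`: 163 nM

In a functional assay on isolated protein for agonist activity at Glucose-dependent insulinotropic receptor (Rattus norvegicus), read by HTRF and cAMP accumulation (on this read-out higher numbers stand for an effect only at larger amounts of compound and lower numbers for an effect already at smaller amounts), compound 3 lies within the scatter of both neighbours: a 1.9-fold lower number from compound 1 to compound 3 (0.29 log units; within the scatter) and a 1.5-fold higher number from compound 2 to compound 3 (0.18 log units; within the scatter). Among the compounds with values here, the one step beyond the scatter, a 2.9-fold lower number from compound 1 to compound 2 (0.47 log units; beyond the scatter), concerns the carbonyl-bearing substituent and not the change now considered.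

Compound 4, `CC(F)Cc1nc(CN2CCC(O[C@H]3CC[C@H](Oc4cnc(S(C)(=O)=O)cn4)CC3)CC2)no1`, differs from compound 3 by 5-(2-fluoropropyl)-1,2,4-oxadiazol-3-yl in place of 1-(trifluoromethyl)cyclopropyl on a saturated chain carbon bound to an amine nitrogen in a ring. Within the data shown here, no measured step bears directly on this exchange; the three steps seen cover a narrow span, one of them modest, the others within the scatter. On that basis compound 4 is expected to give a number near compound 3, with no step beyond the scatter, a 1.0-fold lower number from compound 3 to compound 4 (0.01 log units; within the scatter), so an estimate of 160 nM (range 50 nM to 500 nM) in this assay.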

Compound 4, half-maximal effective concentration: 267 nM
For compound 4 the middle estimate is 1.7-fold (0.22 log units) below the measured one; low and high end bracket the measured number.
By their numbers in this assay, from the lowest: compounds 2, 3, 4 and 1 (each within the scatter of the next, the first and the last beyond it).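

On a saturated chain carbon bound to an amine nitrogen in a ring, 5-(2-fluoropropyl)-1,2,4-oxadiazol-3-yl in place of 1-(trifluoromethyl)cyclopropyl gives a 1.6-fold higher number from compound 3 to compound 4 (0.21 log units; within the scatter) in this assay, so this position accepts a five-membered aromatic ring with 3 hetero atoms without a step beyond the scatter. The new group still gives a 2.5-fold higher number from compound 2 to compound 4 (0.39 log units; beyond the scatter), though only a 1.2-fold lower number from compound 1 to compound 4 (0.07 log units; within the scatter). No supporting data on the cause of these steps are available. Open, as far as these compounds go, is whether a longer chain or a carboxylic acid in place of the 2-fluoropropyl chain would change the number, and what the fluorine on that chain contributes.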